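From a thiazole amide to a bromophenyl anilide

A few compounds are considered here, and "the series" means these few. Any claim that something is new, unique, unknown or untested is made for them only; others in the source may bear on it.

Measured compounds:
compound 1 `O=C(CCCCCCNC(=O)C(O)(O)C(F)(F)F)Nc1nccs1`: 10800 nM
compound 2 `NC(=O)C(=O)NCCCCC(=O)Nc1ccccc1`: > 100000 nM
compound 3 `CCOc1ccc(-c2cnc(NC(=O)CCCCCCNC(=O)C(O)(O)C(F)(F)F)s2)cc1`: 4050 nM

Of the compounds shown here, three have been tested in a functional assay on HCT-116 cells (Homo sapiens) for inhibition, read by colorimetric assay, with a stated time of 3 days; on this read-out higher numbers stand for weaker inhibition and lower numbers for stronger inhibition. Compound 1 gives 10800 nM, the highest of the two plain numbers. Compound 3, which carries a 4-ethoxyphenyl in place of hydrogen on an aromatic carbon of the shared core, gives 4050 nM, so that a 2.7-fold lower number from compound 1 to compound 3 (0.43 log units; beyond the scatter). For compound 2 only a limit is known, > 100000 nM, which marks the edge of what this assay reports rather than a number (the limit of > 100000 nM in this assay, at which 1 of the 3 values shown sits).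

Compound 4 `O=C(CCCCCCNC(=O)C(O)(O)C(F)(F)F)Nc1cccc(Br)c1` differs from compound 1 by 3-bromophenyl in place of 1,3-thiazol-2-yl on an amide-type nitrogen. Going by the values given here, no measured step covers this kind of change; the only step known, from compound 1 to compound 3, alters a different part of the molecule. Among the compounds with values here, compound 2 shares a plain phenyl amide but differs from compound 1 in more than one place, so its limit gives no step. With no direct guide, a weakening beyond the scatter is expected, and the estimate is that a 2.3-fold higher number from compound 1 to compound 4 (0.36 log units; beyond the scatter). Compound 4 is therefore expected to give about 25000 nM, within a range of 6000 nM to 100000 nM.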

Compound 4, half-maximal inhibitory concentration: 3060 nM
Compound 4: the middle estimate sits 8.2-fold (0.91 log units) above what was measured, outside the stated range (below it).
By their numbers in this assay, from the lowest: compounds 4 and 3 (each within the scatter of the next); then compound 1. At a limit, above all of these: compound 2.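

In this assay, putting 3-bromophenyl in place of 1,3-thiazol-2-yl on the amide-type nitrogen gives a 3.5-fold lower number from compound 1 to compound 4 (0.55 log units; beyond the scatter). Going by these compounds alone, this is the first measured change at this position, since the earlier step altered a different part of the molecule, and it shows that the 1,3-thiazol-2-yl group is not required for the activity seen here: a six-membered aromatic ring of carbon only can take its place without loss. The values shown do not explain why the number falls.

The compounds shown leave open whether the bromine itself matters, since a plain phenyl or a 3-methoxyphenyl group on the same chain would separate its role from that of the ring change. Also open, as far as these compounds go, is how a longer chain would behave with the 3-bromophenyl group in place.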